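The source may hold more compounds than are shown below. What is called first, only, known or untested is meant among the compounds shown, and "the series" means these compounds.

In a functional assay, with stated times of 30 s and 6 min, in the presence of a further agent that is not named here (on this read-out higher numbers stand for weaker inhibition and lower numbers for stronger inhibition), compound 2 (`CCCCCCOc1cc(OC)ccc1C(C)=O`) gives 18000000 nM, and compound 1 (`CCCCCCCCOc1cc(OC)c(Br)cc1C(C)=O`) gives 30900000 nM. Among the measured compounds shown here, these two numbers lie within the scatter of each other, so compound 2 cannot be separated from the only other compound measured so far. Compound 3 (`CCCCCCCCOc1cc(OC)ccc1C(C)=O`) has not yet been measured. Its structure departs from that of compound 2 in one place: ethyl in place of hydrogen on a saturated chain carbon, six bonds along the chain from an oxygen on an aromatic ring. The change is ethyl in place of hydrogen on a saturated chain carbon, six bonds along the chain from an oxygen on an aromatic ring. For the measured compounds named here, no measured pair shows the effect of such a change in this assay, so the expectation starts from compound 2 at 18000000 nM, and no step beyond the scatter is foreseen. The expected step is a 1.1-fold lower number from compound 2 to compound 3 (0.05 log units; within the scatter). The estimate for compound 3 is 16000000 nM, with an expected range of 5000000 nM to 45000000 nM.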

Compound 3, half-maximal inhibitory concentration: 21200000 nM
Compound 3: the middle estimate sits 1.3-fold (0.12 log units) below what was measured, within the range that was stated.
By their numbers in this assay, from the lowest: compounds 2, 3 and 1 (each within the scatter of the next).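

In this assay, ethyl in place of hydrogen on a saturated chain carbon, six bonds along the chain from an oxygen on an aromatic ring, gives a 1.2-fold higher number from compound 2 to compound 3 (0.07 log units; within the scatter), so this change at this position cannot be told from no change on this read-out. Hydrogen in place of bromo on an aromatic carbon, now seen as a single change, gives a 1.5-fold lower number from compound 1 to compound 3 (0.16 log units; within the scatter), and it too cannot be told from no change. Nothing measured here offers a reason for either result.

The compounds shown leave open whether a longer chain, or a chain ending in an amine or a carboxylic acid, at this saturated chain carbon would give a step beyond the scatter in this assay. They also leave open whether a nitrile or a trifluoromethyl group in place of bromo on that aromatic carbon would do so.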